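Chloro to Hydrogen on the Aryl Ring of Compound 3

The source may hold more compounds than are shown below. What is called first, only, known or untested is meant among the compounds shown, and "the series" means these compounds.

Of the compounds shown here, three sharing one core have been tested in a functional assay on HCT-116 cells (Homo sapiens) for antiproliferative activity, read by CCK-8 assay, with a stated time of 72 h; a higher number here means a weaker inhibitor, a lower number a stronger inhibitor. Compound 1 `CC1=NN(c2ccc(C)cc2)C(=O)C12C=CC(=O)C=C2c1ccc(C)cc1` gives 9710 nM in this assay. Compound 3 `CC1=NN(c2ccc(Cl)cc2)C(=O)C12C=CC(=O)C=C2c1ccc(C)cc1` gives 10300 nM. For compound 2 `CC1=NN(c2ccccc2)C(=O)C12C=CC(=O)C=C2c1cccc(C)c1` this assay reports only a limit, > 100000 nM, and not a number. Of the two numbers, compound 3 carries the higher one, but its gap to compound 1 is small: the step of a 1.1-fold higher number from compound 1 to compound 3 (0.03 log units; within the scatter) shows that chloro in place of methyl on the aromatic carbon left the read-out essentially unchanged.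

Compound 4 `CC1=NN(c2ccccc2)C(=O)C12C=CC(=O)C=C2c1ccc(C)cc1` has not yet been measured. It differs from compound 3 by hydrogen in place of chloro on an aromatic carbon. Among the measured compounds shown here, the only measured step touching the same aromatic carbon, a 1.1-fold higher number from compound 1 to compound 3 (0.03 log units; within the scatter), lies within the scatter, so a further change there is expected to move the number little, if at all. Compound 4 is therefore expected to give 12000 nM in this assay, with a range from 5000 nM to 40000 nM. The step this expectation implies, a 1.2-fold higher number from compound 3 to compound 4 (0.07 log units; within the scatter), is expected to stay within the scatter.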

Compound 4, half-maximal inhibitory concentration: 27100 nM
Compound 4: the middle estimate sits 2.3-fold (0.35 log units) below what was measured; low and high end bracket the measured number.
By their numbers in this assay, from the lowest: compounds 1 and 3 (each within the scatter of the next); then compound 4. At a limit, above all of these: compound 2.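

At this aromatic carbon, para to a large group, chloro and methyl read alike, but hydrogen does not: replacing chloro gives a 2.6-fold higher number from compound 3 to compound 4 (0.42 log units; beyond the scatter), and replacing methyl gives a 2.8-fold higher number from compound 1 to compound 4 (0.45 log units; beyond the scatter). In these three compounds, then, either group at this carbon goes with a lower number than hydrogen, so the position is not indifferent to change, as the first step alone suggested. On the double-bonded ring carbon, 4-methylphenyl in place of 3-methylphenyl gives an at least 3.6-fold lower number from compound 2 to compound 4 (0.56 log units; beyond the scatter), and this step starts from a limit for compound 2, not a number: the limit of > 100000 nM in this assay, at which 1 of the 4 values shown sits.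

Going by these compounds, whether a different group on this aromatic carbon, such as an amine or a carboxylic acid, would lower the number further stays open. Why hydrogen differs from chloro and methyl also stays open.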